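The source may hold more compounds than are shown below. What is called first, only, known or untested is meant among the compounds shown, and "the series" means these compounds.

Measured so far in a physicochemical assay for acid dissociation, using potentiometric titration:
compound 1 `O=c1ccn(CCN2CCCCC2)c(CO)c1O` — compound 1 gives 7.35
compound 2 `Cn1cc(O)c(=O)cc1CN1CCCCC1` — compound 2 gives 6.74
compound 3 `CCc1c(O)c(=O)ccn1CCCn1ccnc1` — compound 3 gives 6.55

Compound 1 stands highest of the three in this assay; compound 2 lies nearest to it, lower by a gap beyond the scatter, and compound 3 lies furthest, also lower beyond the scatter. No pair among these differs in one place only, so no single step is known.

Compound 4 `CC(O)c1c(O)c(=O)ccn1CCN1CCCCC1` has not yet been measured. It differs from compound 1 in one place: methyl in place of hydrogen on a saturated chain carbon bound to an aromatic carbon and an oxygen on a saturated carbon. Read one bond further out, the change is hydroxymethyl to 1-hydroxyethyl, on a saturated chain carbon bound to an aromatic carbon and an oxygen on a saturated carbon.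

For the measured compounds named here, nothing among the measured compounds tests this change directly. The shift is expected to be small, with a step from compound 1 to compound 4 of a number 0.05 log units higher from compound 1 to compound 4 (within the scatter) in this assay, not beyond the scatter. Compound 4 is therefore estimated at 7.4, within 7 to 7.8.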

Compound 4, acid dissociation constant: 7.37
Beside the measured number, compound 4's estimate is 0.03 log units above it; the range from low to high includes it.
By their numbers in this assay, from the lowest: compounds 3 and 2 (each within the scatter of the next); then compounds 1 and 4 (each within the scatter of the next).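

Hydroxymethyl to 1-hydroxyethyl is the first single change that can be read in this series, and in this assay it gives a number 0.02 log units higher from compound 1 to compound 4 (within the scatter). Methyl in place of hydrogen on this saturated chain carbon therefore stays inside the scatter, which the earlier compounds, with no single step among them, could not show. No measurement bears on the origin of this step.

Still open, going by these compounds, is whether a longer chain, an amine or a carboxylic acid on this same carbon would also stay inside the scatter. A methoxy group in place of the hydroxyl on this chain is equally untested among the compounds shown.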